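This account rests on a few compounds, and the source may have more. Where it says the series, first, only, none or still open, it means among the compounds named here.

The series in view is a set of three measured acids around a shared core, all tested in an in vitro functional assay on HEK285-7 cells for antagonist activity at prostaglandin D2 receptor 2 (Homo sapiens), read by BRET and beta-arrestin recruitment; a higher number here means a larger maximal response, a lower number a smaller maximal response. Compound 1, `COc1ccc(OC)c(-c2nc(C(c3ccccc3)c3ccccc3)sc2CC(=O)O)c1`, gives 80% in this assay. Compound 2, `COc1cc(-c2nc(C(c3ccc(F)cc3)c3ccc(F)cc3)sc2CC(=O)O)ccn1`, gives 60% in this assay. Compound 3, `O=C(O)Cc1sc(C(c2ccccc2)c2ccc(Cl)cc2)nc1-c1ccc(F)cc1`, gives 80% in this assay. Among these three numbers compound 2 stands lowest: both compound 1 and compound 3 sit above it by more than the usual scatter, and they sit at the same distance from it, so there is no nearer or farther neighbour to speak of.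

The next step goes from compound 2 to compound 4, `O=C(O)Cc1sc(C(c2ccc(F)cc2)c2ccc(F)cc2)nc1-c1ccc(Cl)cc1`, which has not yet been measured in this assay. The change is 4-chlorophenyl in place of 2-methoxypyridin-4-yl on an aromatic carbon.

Among the measured compounds shown here, no measured pair in the set differs by exactly this change, so the expectation rests on the values themselves. Compound 4 carries on its diphenylmethyl side the same two fluorine-bearing rings as compound 2, and on the aromatic carbon the 4-chlorophenyl resembles the halophenyl of compound 3, which gives 80%. Compound 4 is therefore expected to move upward, with the step of a number 15 percentage points higher from compound 2 to compound 4 (beyond the scatter) expected to lie beyond the scatter. Compound 4 is estimated at 75%, within a range from 60% to 90%.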

Compound 4, largest response reached (reported as efficacy), in percent of the reference or control that the assay uses: 80%
For compound 4 the middle estimate is 5 percentage points below the measured one; measured number inside the range.
By their numbers in this assay, from the lowest: compound 2; then compounds 1, 3 and 4 (each within the scatter of the next).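

This step gives the set its first comparison of compounds that differ in one place: on the aromatic carbon next to the ring nitrogen and next to the ring atom that bears a carboxymethyl group, 4-chlorophenyl in place of 2-methoxypyridin-4-yl gives, in this assay, a number 20 percentage points higher from compound 2 to compound 4 (beyond the scatter) and so lies beyond the scatter. Among the compounds shown here, the position therefore responds to this exchange of one six-membered aromatic ring for another while the rest of compound 2 stays the same, a link that the earlier compounds, which differ in more than one place, could not show. The exchange replaces a ring with one hetero atom and two hydrogen-bond acceptors by an all-carbon ring with none and adds chlorine, but nothing here bears on which of these differences accounts for the step.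

The compounds shown leave open whether the step follows the chlorine, the ring nitrogen or the methoxy group, which a plain phenyl, a 4-methoxyphenyl or an unsubstituted pyridin-4-yl at this position would separate. They also leave open how an amine or a carboxylic acid on this ring would read out, and whether the same exchange gives a similar step with other groups on the rest of the core.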